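Bromo-hydroxyphenyl analogue of a KIF15 series

A few compounds are considered here, and "the series" means these few. Any claim that something is new, unique, unknown or untested is made for them only; others in the source may bear on it.

Measured so far:
compound 1, `O=C1Nc2ccc(C(=O)c3ccco3)cc2/C1=C/c1cc(F)c(O)c(Br)c1`, 38% in an assay on HeLa cells for inhibition of Kinesin-like protein KIF15 (Homo sapiens), read by microscopy, with stated times of 2 s and 20 s, tested at 750 nM; on this read-out higher numbers stand for more inhibition at the one concentration tested (going by the name of the read-out) and lower numbers for less inhibition
compound 2, `Cc1cc(/C=C2\C(=O)Nc3ccc(C(=O)c4ccco4)cc32)cc(C)c1O`, 9%
compound 3, `COc1c(Br)cc(/C=C2\C(=O)Nc3ccc(C(=O)c4ccco4)cc32)cc1Br`, -12.6%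

Compound 2 stands second highest of the three in this assay, its number lying beyond the scatter from both compound 1 and compound 3. Compound 4, `O=C1Nc2ccc(C(=O)c3ccco3)cc2/C1=C/c1ccc(O)c(Br)c1`, is not yet measured. It differs from compound 2 by 3-bromo-4-hydroxyphenyl in place of 4-hydroxy-3,5-dimethylphenyl on a double-bonded chain carbon bound to a double-bonded ring carbon. Among the compounds with values here, the one measured step that bears on this, a number 29 percentage points lower from compound 1 to compound 2 (beyond the scatter), shows that swapping a bromine-bearing hydroxyphenyl group for the dimethyl one cost a modest amount of inhibition. Compound 4 brings the bromine back while leaving out the fluorine of compound 1, so a rise partway back is expected: a number 17 percentage points higher from compound 2 to compound 4 (beyond the scatter). Compound 4 is therefore estimated at 26%, within 8% to 44%.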

Compound 4, a percentage reported as inhibition, at one concentration (the size of the read-out at that concentration, not a potency): 23%
Compound 4: the middle estimate sits 3 percentage points above what was measured; the measured number falls inside the stated range.
By their numbers in this assay, from the lowest: compound 3; then compound 2; then compound 4; then compound 1.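

In this assay, 3-bromo-4-hydroxyphenyl in place of 4-hydroxy-3,5-dimethylphenyl gives a number 14 percentage points higher from compound 2 to compound 4 (beyond the scatter), so a bromine-bearing ring without fluoro still stands above the dimethyl one. Hydrogen in place of fluoro on an aromatic carbon gives a number 15 percentage points lower from compound 1 to compound 4 (beyond the scatter), which separates the fluoro change from the larger swap seen earlier. Nothing measured here gives a reason for either step. Still open, from the compounds shown here alone, is how chloro in place of the bromine, or an amine in place of the hydroxy group, would read on this scale.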